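Replacing a Bulky Aryl Group: Expectations for Compound 4

A few compounds are considered here, and "the series" means these few. Any claim that something is new, unique, unknown or untested is made for them only; others in the source may bear on it.

Compound 1 `CC(C)(C)c1ccc(-c2nnc(SCCCN3CCN(c4ccccc4)CC3)[nH]2)cc1` — in a functional assay on MCF7 cells (Homo sapiens) for cytotoxicity, read by MTT assay, with a stated time of 24 h (a lower number here means a stronger inhibitor, a higher number a weaker inhibitor), compound 1 gives > 300000 nM
Compound 2 `CCN1CCN(CCCSc2nnc(-c3ccc(C)cc3)[nH]2)CC1` — compound 2 gives > 300000 nM
Compound 3 `Clc1ccc(-c2nnc(SCCCN3CCN(c4cccc(Cl)c4)CC3)[nH]2)cc1` — compound 3 gives > 300000 nM

Of the compounds shown here, three of this shared core have been tested in this assay. Compound 1 returns only a limit there, > 300000 nM, not a number. Compound 2 likewise stops at a limit, > 300000 nM. Compound 3 also reaches only a limit, > 300000 nM. Among the compounds with values here, compound 1 thus stands exactly where every measured compound stands: at the limit of > 300000 nM in this assay, at which 3 of the 3 values shown sit, with nothing measured below it and no step between measured compounds to lean on.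

Compound 4 `Cc1cccc(-c2nnc(SCCCN3CCN(c4ccccc4)CC3)[nH]2)c1` is not yet measured. It differs from compound 1 by 3-methylphenyl in place of 4-(tert-butyl)phenyl on an aromatic carbon. The three measured compounds carry three different aryl groups on that carbon, and none of them yields a number. The expectation for compound 4 is therefore no step beyond the scatter, an estimated change of a step that the limit leaves unreadable from compound 1 to compound 4. Compound 4 is expected to sit near 500000 nM, between 150000 nM and 2000000 nM, most likely reported again as a limit rather than a number.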

Compound 4, half-maximal inhibitory concentration: > 300000 nM
Compound 4 was reported as a limit; the forecaster's own chance of this, stated with the estimate: 85%; the middle value does not contradict the limit.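

Compound 4, like compound 1, returns only a limit in this assay, so no step can be read between them. The compounds shown leave open whether any change on the shared core would yield a number rather than a limit, for all stand at one place: the limit of > 300000 nM in this assay, at which 4 of the 4 values shown sit.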